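The compounds below may be only part of what the source reports. "The series", "measured", "known", "first", "only" and "open" are said of these compounds alone.

Of the compounds shown here, two have been measured so far. In a functional assay on SK-MEL-2 cells (Homo sapiens) for cytotoxicity (a higher number here means that more compound is needed for the effect, a lower number that less compound is needed), compound 1 `CCCCC/C=C\C[C@@H](O)[C@H](O)/C=C/[C@@H]1C/C=C\CCCC(=O)O1` gives 12.4 ug/mL, and compound 2 `CCCCC/C=C\C[C@H](O)C(/C=C/[C@@H]1C/C=C\CCCC(=O)O1)OC` gives 8.6 ug/mL. Going by the values given here, compound 2 has the lowest of the two numbers, but its only neighbour, compound 1, lies within the scatter of it, so the two cannot be told apart on these data. The next compound, compound 3 `CC/C=C\C/C=C\C[C@H](O)C(/C=C/[C@@H]1C/C=C\CCCC(=O)O1)OC`, has not yet been measured. It differs from compound 2 in a single place: but-1-en-1-yl in place of butyl on a saturated chain carbon bound to a double-bonded chain carbon. Among the compounds with values here, no step between measured compounds is on record, so there is no earlier change to lean on; what can be said is that the group entering has the same count of heavy atoms as the group leaving, with one double bond added. The expectation is therefore no step beyond the scatter, a 1.0-fold lower number from compound 2 to compound 3 (0.01 log units; within the scatter). Compound 3 is estimated at 8.5 ug/mL in this assay, with a likely range from 4 ug/mL to 18 ug/mL.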

Compound 3, concentration for half-maximal effect: 4.3 ug/mL
The estimate for compound 3 lay 2.0-fold (0.30 log units) above the measured number, within the range that was stated.
By their numbers in this assay, from the lowest: compounds 3, 2 and 1 (each within the scatter of the next, the first and the last beyond it).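

Going by these compounds alone, this is the only step on record at this position: but-1-en-1-yl in place of butyl on a saturated chain carbon bound to a double-bonded chain carbon gives, in this assay, a 2.0-fold lower number from compound 2 to compound 3 (0.30 log units; within the scatter). On this single pair, adding one double bond while keeping the count of heavy atoms the same yields two compounds that cannot be told apart. No other measurement bears on this result.

From the compounds shown here alone, it remains open whether a different group at this place, such as propyl, a longer chain like hexyl, or a chain ending in an amine, would give a step beyond the scatter. Going by these compounds, it is also open whether the same added double bond would give a similar step on compound 1, whose core differs.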